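The source may report more compounds than this note shows. Statements on the series, on what has been measured and on what is new or still open speak of the compounds shown alone.

Compound 1 `CC1CCN(c2c(S(=O)(=O)c3cc(Cl)cc(Cl)c3)cnc3ccc(Cl)cc23)CC1`, compound 2 `Cc1ccc(S(=O)(=O)c2cnc3ccc(Cl)cc3c2N2CCC(C)CC2)cc1F` and compound 3 `COc1ccc(S(=O)(=O)c2cnc3ccc(Cl)cc3c2N2CCC(C)CC2)cc1Cl` share one core and differ only in the aryl group on the sulfonyl sulfur. In an assay on isolated protein for displacement of a labelled ligand from metabotropic glutamate receptor 5 (Homo sapiens), with a stated time of 60 min, tested at 1 uM (on this read-out higher numbers stand for more inhibition at the one concentration tested (going by the name of the read-out) and lower numbers for less inhibition), compound 1 gives 88%, compound 2 gives 68% and compound 3 gives 46%, the lowest of the three: a number 42 percentage points lower from compound 1 to compound 3 (beyond the scatter) and a number 22 percentage points lower from compound 2 to compound 3 (beyond the scatter). Compound 4 `CC1CCN(c2c(S(=O)(=O)c3cccc(F)c3)cnc3ccc(Cl)cc23)CC1` is not yet measured; it carries 3-fluorophenyl in place of 3-chloro-4-methoxyphenyl on a sulfonyl sulfur. All three measured steps alter this same aryl group, and the step of a number 20 percentage points lower from compound 1 to compound 2 (beyond the scatter) shows that a halogen-bearing phenyl without methoxy sits between the extremes. Compound 4 is therefore expected to rise, by about a number 16 percentage points higher from compound 3 to compound 4 (beyond the scatter), because compound 2 gives 68% with a related aryl. For compound 4 the estimate in this assay is 62%, ranging from 42% to 82%.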

Compound 4, a percentage reported as inhibition, at one concentration (the size of the read-out at that concentration, not a potency): 58%
Compound 4: the middle estimate sits 4 percentage points above what was measured; low and high end bracket the measured number.
By their numbers in this assay, from the lowest: compound 3; then compounds 4 and 2 (each within the scatter of the next); then compound 1.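

On the sulfonyl sulfur, compound 4 shows that the methyl group of compound 2 can go without a change beyond the scatter in this assay: hydrogen in its place gives a number 10 percentage points lower from compound 2 to compound 4 (within the scatter). The 3-fluorophenyl group still stands apart from both 3-chloro-4-methoxyphenyl (a number 12 percentage points higher from compound 3 to compound 4 (beyond the scatter)) and 3,5-dichlorophenyl (a number 30 percentage points lower from compound 1 to compound 4 (beyond the scatter)), so compound 1 stays clear of all three others. Nothing available explains these differences. From the compounds shown here alone, how a trifluoromethyl group, a nitrile or an amine on this aryl ring would read in this assay remains open.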